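The source may report more compounds than this note shows. Statements on the series, on what has been measured and on what is new or still open speak of the compounds shown alone.

Working notes on the series.

Compound 1 `CCOc1cc(/C=C/C(=O)c2ccncc2)cc(OCC)c1OCC` gives 92 nM in an assay on cell membranes for inhibition of cytochrome P450 1A1 (Homo sapiens), read by fluorescence, using microsomes, with a stated time of 10 min; on this read-out lower numbers stand for stronger inhibition and higher numbers for weaker inhibition. Among the three numbers in hand it stands second highest. Its nearest neighbour is compound 3 `COc1cc(/C=C/C(=O)c2ccncc2)cc(OC)c1OC`, which in this assay gives 61 nM; the gap between compound 1 and compound 3 lies within the scatter. Furthest away is compound 2 `COc1ccccc1/C=C/C(=O)c1ccncc1`, which gives 570 nM in this assay, a gap beyond the scatter, with compound 2 the weaker inhibitor of the two.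

Compound 4 `CCOc1cc(/C=C/C(=O)c2ccncc2)cc(OC)c1OCC` is not yet measured. It differs from compound 1 in one place: hydrogen in place of methyl on a saturated chain carbon bound to an oxygen on an aromatic ring, that is, ethoxy becomes methoxy at that one position. Compound 3 carries methoxy at every such position and compound 1 ethoxy at every such position, and the two sit within the scatter of each other. A single ethoxy to methoxy exchange between them is therefore not expected to move the number beyond the scatter; the step from compound 1 to compound 4 is expected to be a 1.2-fold lower number from compound 1 to compound 4 (0.06 log units; within the scatter). For compound 4 the expected value in this assay is 80 nM, with a range from 40 nM to 160 nM.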

Compound 4, half-maximal inhibitory concentration: 65 nM
Beside the measured number, compound 4's estimate is 1.2-fold (0.09 log units) above it, within the range that was stated.
By their numbers in this assay, from the lowest: compounds 3, 4 and 1 (each within the scatter of the next); then compound 2.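

Going by these compounds alone, the pair compound 1 and compound 4 is the first to differ in one place, so the exchange of ethoxy to methoxy can now be read on its own: in this assay it gives a 1.4-fold lower number from compound 1 to compound 4 (0.15 log units; within the scatter). At this position, on the core of compound 1, the read-out therefore does not separate ethoxy from methoxy, a result that holds for this one pair only. Nothing at hand accounts for this result.

The compounds shown leave open whether a longer chain such as butoxy, or an amine or a carboxylic acid carried on the same oxygen, would also stay within the scatter of compound 1. They also leave open whether the same single exchange, made at either of the other ethoxy groups of compound 1, would read the same.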